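Moving two methyls into one ethyl on the aryl ether

A few compounds are considered here, and "the series" means these few. Any claim that something is new, unique, unknown or untested is made for them only; others in the source may bear on it.

Compound 1 `O=C(O)CCc1ccc(NC(=O)c2nnc(COc3ccc4c(c3)CCC4)s2)cc1` and compound 2 `Cc1ccc(OCc2nnc(C(=O)Nc3ccc(CCC(=O)O)cc3)s2)cc1C` share one core and differ only in the aromatic group carried on an oxygen on a saturated carbon. In a functional assay on CHO cells for agonist activity at Free fatty acid receptor 1 (Homo sapiens), read by FLIPR and calcium flux, tested at 1 uM (a higher number here means that more compound is needed for the effect, a lower number that less compound is needed), compound 1 gives 1380 nM, and in the same assay compound 2 gives 1130 nM. The change between them, a 1.2-fold lower number from compound 1 to compound 2 (0.09 log units; within the scatter), is too small to count as a real difference, so the two compounds stand on the same footing; compound 2 simply has the lower of the two numbers, with compound 1 close behind.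

Compound 3 `CCc1ccc(OCc2nnc(C(=O)Nc3ccc(CCC(=O)O)cc3)s2)cc1` has not yet been measured. It keeps every atom of compound 2 and rearranges only the aryl group: 4-ethylphenyl in place of 3,4-dimethylphenyl on an oxygen on a saturated carbon. Going by the values given here, the single measured step, from compound 1 to compound 2, bears on this kind of change, since it also swapped one small hydrocarbon aryl group for another at the same oxygen, and it stayed within the scatter. The expectation for compound 3 is therefore a step of about a 1.1-fold higher number from compound 2 to compound 3 (0.03 log units; within the scatter), with no movement beyond the scatter in either direction. Compound 3 is estimated at 1200 nM, expected to fall between 500 nM and 2900 nM.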

Compound 3, half-maximal effective concentration: 1170 nM
Beside the measured number, compound 3's estimate is 1.0-fold (0.01 log units) above it; the range from low to high includes it.
By their numbers in this assay, from the lowest: compounds 2, 3 and 1 (each within the scatter of the next).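

In this assay, folding the two methyls of 3,4-dimethylphenyl into the single ethyl of 4-ethylphenyl, on an oxygen on a saturated carbon, gives a 1.0-fold higher number from compound 2 to compound 3 (0.02 log units; within the scatter), and replacing 2,3-dihydro-1H-inden-5-yl with the same 4-ethylphenyl gives a 1.2-fold lower number from compound 1 to compound 3 (0.07 log units; within the scatter). Going by these compounds alone, the earlier pair held only two aryl groups at this place; there are now three, all built of carbon and hydrogen, and none can be told apart from the others, even when compound 2 and compound 3 have the same atoms joined differently. For these three groups, then, rearranging the carbons on the aryl ring leaves the number within the scatter, and no supporting measurement is available to explain this result.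

All three groups contain only carbon and hydrogen, so the compounds shown leave open whether the number would hold with a methoxy, a chlorine or a nitrile on the phenyl ring. They also leave open whether a longer chain, as in 4-butylphenyl, or a plain unsubstituted phenyl would move the number beyond the scatter.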